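The source may hold more compounds than are shown below. What is called first, only, known or untested is meant among the compounds shown, and "the series" means these compounds.

Working notes on the series. The shared core carries a cyclopropyl-substituted amino linker to a glycinamide, and the compounds differ in the amino-acid residue and its ester. Compound 1 `O=C(CN(c1nc(Cl)nc2[nH]cnc12)C1CC1)NCC(=O)OCc1ccccc1` gives 18% in a functional assay on the whole organism (Tail, strain ICR) with Mus musculus as the target, in the tail flick test, with a stated time of 150 min, at a dose of 25 umol/kg by the oral route; on this read-out higher numbers stand for a stronger effect at the one dose given and lower numbers for a weaker effect. Among the three measured numbers its nearest neighbour is compound 2 `O=C(CN(c1nc(Cl)nc2[nH]cnc12)C1CC1)N[C@@H](CO)C(=O)O`, which gives 18.8%; the furthest is compound 3 `O=C(O)CNC(=O)CN(c1nc(Cl)nc2[nH]cnc12)C1CC1`, which gives 9.08%, so that a number 8.9 percentage points lower from compound 1 to compound 3 (within the scatter) is recorded. The second measured step, a number 9.7 percentage points lower from compound 2 to compound 3 (within the scatter), touches the same saturated chain carbon that is altered in compound 4.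

Compound 4 `CC[C@H](C)[C@H](NC(=O)CN(c1nc(Cl)nc2[nH]cnc12)C1CC1)C(=O)OCc1ccccc1` is reached from compound 1 by one change: sec-butyl in place of hydrogen on a saturated chain carbon bound to an amide-type nitrogen and a carbonyl carbon. Within the data shown here, no measured step adds a sec-butyl group at this place; the only step at this carbon, a number 9.7 percentage points lower from compound 2 to compound 3 (within the scatter), stayed within the scatter, as did the step at the ester, a number 8.9 percentage points lower from compound 1 to compound 3 (within the scatter). Among the measured compounds shown here, nothing measured so far has moved this assay beyond the scatter, so the expected step for compound 4 is a number 2 percentage points higher from compound 1 to compound 4 (within the scatter), that is, no change beyond the scatter. Compound 4 is therefore expected to give about 20% in this assay, with a range from 5% to 38%.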

Compound 4, a percentage reported as activity, at one dose (the size of the read-out at that dose, not a potency): 6.9%
For compound 4 the middle estimate is 13.1 percentage points above the measured one, and the stated range covers the measured number.
By their numbers in this assay, from the lowest: compounds 4, 3, 1 and 2 (each within the scatter of the next, the first and the last beyond it).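

In this assay, among these compounds, sec-butyl in place of hydrogen on a saturated chain carbon bound to an amide-type nitrogen and a carbonyl carbon gives a number 11.1 percentage points lower from compound 1 to compound 4 (beyond the scatter), and this is the first step to pass the scatter. This carbon, where the earlier step of a number 9.7 percentage points lower from compound 2 to compound 3 (within the scatter) stayed within the scatter, can therefore move the read-out, and with the benzyl ester in place the addition of sec-butyl lowers the number, though the effect rests on this one modest step. No supporting data bear on why the number falls at this position, so the step stands as an observation only.

The compounds shown leave open whether the fall follows from sec-butyl specifically, since this carbon carries only hydrogen, hydroxymethyl or sec-butyl here, and a methyl group, a longer straight chain, a phenyl ring or a side chain ending in an amine could each give a different result. They also leave open whether the opposite configuration at the defined stereocentre, or a free carboxylic acid in place of the benzyl ester, would retain the same step.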